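Removing a Chloro Group: Expected Effect on Inhibition

The compounds below may be only part of what the source reports. "The series", "measured", "known", "first", "only" and "open" are said of these compounds alone.

Compound 1 `O=C1/C(=C/c2ccccc2)CCC/C1=C\c1ccccc1Cl`: 43%
Compound 2 `O=C(/C=C(O)/C=C/c1cccc(O)c1)c1cc(Cl)ccc1O`: 62.4%

Of the compounds shown here, two have been tested in an assay on isolated protein for inhibition of Alpha glucosidase (Homo sapiens), with stated times of 5 min and 15 min, tested at 50 uM; a lower number here means less inhibition, a higher number more inhibition at the concentration tested (going by the name of the read-out). Compound 2 shows the higher of the two numbers, and compound 1 lies lower by a gap beyond the usual scatter. Compound 3 `O=C(/C=C(O)/C=C/c1cccc(O)c1)c1ccccc1O` has not yet been measured in this assay. Compared with compound 2, compound 3 carries hydrogen in place of chloro on an aromatic carbon. Going by the values given here, no step between measured compounds bears on this change, so the expectation rests on compound 2 alone. The step of a number 10.4 percentage points lower from compound 2 to compound 3 (beyond the scatter) is expected to be a modest loss, possibly within the scatter. The estimated value for compound 3 is 52%, with a range from 32% to 70%.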

Compound 3, a percentage reported as inhibition, at one concentration (the size of the read-out at that concentration, not a potency): 40.4%
Compound 3: middle estimate off by 11.6 percentage points, on the high side; the measured number falls inside the stated range.
By their numbers in this assay, from the lowest: compounds 3 and 1 (each within the scatter of the next); then compound 2.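

In this assay, putting hydrogen in place of the chloro group on this aromatic carbon, para to a hydroxy group, gives a number 22 percentage points lower from compound 2 to compound 3 (beyond the scatter). This direct pair shows that, on this shared core, inhibition at the concentration tested depends on the chloro group at this place. The data offer no explanation for this loss. On these data alone, whether a bromo group, a methoxy group or an amine at this place would match the chloro group remains open, as does whether the step would hold at other concentrations.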